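A few compounds are considered here, and "the series" means these few. Any claim that something is new, unique, unknown or untested is made for them only; others in the source may bear on it.

Compound 1 `Cn1c(=O)c(=O)n(C2CCCC2)c2nc(N/N=C/c3ccccc3)ncc21`: > 100000 nM
Compound 2 `COc1ccc(/C=N/Nc2ncc3c(n2)n(C2CCCC2)c(=O)c(=O)n3C)cc1`: 36100 nM

In a functional assay on HCT-116 cells (Homo sapiens) for antiproliferative activity, read by MTT assay (on this read-out lower numbers stand for stronger inhibition and higher numbers for weaker inhibition), compound 1 gives > 100000 nM, which is a limit of the assay and not a number. In this assay, among the compounds with values here, compound 2 gives 36100 nM, and this is the only actual number among the values shown, so compound 2 stands as the one measured point. Within the data shown here, the one further value shown, that of compound 1, is a limit, as noted in the limit of > 100000 nM in this assay, at which 1 of the 2 values shown sits. Among the measured compounds shown here, the step of an at least 2.7-fold lower number from compound 1 to compound 2 (0.44 log units; beyond the scatter) is the only measured step here.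

Compound 3 `Cn1c(=O)c(=O)n(C2CCCC2)c2nc(N/N=C/c3cccc([N+](=O)[O-])c3)ncc21` differs from compound 2 by 3-nitrophenyl in place of 4-methoxyphenyl on a carbon with a double bond to nitrogen. The measured step concerns a methoxy entering in place of hydrogen on the same aromatic ring, not a swap of one substituent for another, so it bears on this change only loosely: it shows that a substituent on this ring can shift this assay by at least a modest amount. Compound 3 is therefore expected to land not far from compound 2, with a possible shift toward weaker inhibition, a step estimated as a 1.5-fold higher number from compound 2 to compound 3 (0.18 log units; within the scatter). The estimate for compound 3 in this assay is 55000 nM, within 15000 nM to 150000 nM.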

Compound 3, half-maximal inhibitory concentration: 15200 nM
Compound 3: middle estimate off by 3.6-fold (0.56 log units), on the high side; the range from low to high includes it.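

In this assay, replacing 4-methoxyphenyl with 3-nitrophenyl on the carbon with a double bond to nitrogen gives a 2.4-fold lower number from compound 2 to compound 3 (0.38 log units; beyond the scatter), so the choice of substituted ring matters, and not only whether the ring carries a substituent. Nitro in place of hydrogen on an aromatic carbon gives an at least 6.5-fold lower number from compound 1 to compound 3 (0.81 log units; beyond the scatter), which makes nitro the second substituent shown, after methoxy, to lower the number relative to the plain phenyl ring, with no compound shown going against this. The size of that step remains open-ended, since the value of compound 1 is a limit and not a number: the limit of > 100000 nM in this assay, at which 1 of the 3 values shown sits.

The swap from compound 2 to compound 3 changes both the group and its printed ring position in a single step, so the compounds shown cannot separate the effect of nitro replacing methoxy from that of the shift from 4- to 3-substitution. On these data alone, it also remains open whether an amine, a carboxylic acid or a halogen such as chlorine on this ring would lower the number further, leave it unchanged or raise it.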